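The compounds below may be only part of what the source reports. "The series", "measured", "known", "first", "only" and "open" are said of these compounds alone.

Of the compounds shown here, three built on a shared core have so far been tested in a functional assay on A549 cells (Homo sapiens) for cytotoxicity, read by MTT assay, with a stated time of 72 h; on this read-out higher numbers stand for weaker inhibition and lower numbers for stronger inhibition. Compound 1 `COc1cccc(/C=C2\CCC/C(=C\c3cccc(Cl)c3)C2=O)c1OC` gives only a limit of the assay, > 20000 nM. Compound 2 `COc1ccc(/C=C2\CCC/C(=C\c3cccc(OC)c3OC)C2=O)c(OC)c1` likewise gives only a limit, > 20000 nM. Compound 3 `COc1ccc(/C=C2\CCC/C(=C\c3cccc(Br)c3)C2=O)cc1OC` is the sole one with an actual number in this assay, 12800 nM. The other two values stand at the limit of > 20000 nM in this assay, at which 2 of the 3 values shown sit. Compound 4 `COc1cc(/C=C2\CCC/C(=C\c3ccc(OC)c(OC)c3)C2=O)ccc1O` has not yet been measured in this assay. It differs from compound 3 in one place: 4-hydroxy-3-methoxyphenyl in place of 3-bromophenyl on a double-bonded chain carbon bound to a double-bonded ring carbon. Within the data shown here, no measured pair in this set shares that change, so only a modest expectation can be formed. The value for compound 4 is estimated at 9000 nM, within a range from 2500 nM to 20000 nM. This estimate amounts to an expected step of a 1.4-fold lower number from compound 3 to compound 4 (0.15 log units; within the scatter), not clearly beyond the usual scatter.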

Compound 4, half-maximal inhibitory concentration: 10300 nM
Beside the measured number, compound 4's estimate is 1.1-fold (0.06 log units) below it, and the stated range covers the measured number.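

In this assay, 4-hydroxy-3-methoxyphenyl in place of 3-bromophenyl on a double-bonded chain carbon bound to a double-bonded ring carbon gives a 1.2-fold lower number from compound 3 to compound 4 (0.09 log units; within the scatter). This first readable step shows that a group with a hydrogen-bond donor and acceptors can replace one with neither, with no change beyond the scatter. The other values give no number to compare: the limit of > 20000 nM in this assay, at which 2 of the 4 values shown sit.

This single step cannot separate losing the bromine from gaining the hydroxy and methoxy groups. Going by these compounds, what an amine or a carboxylic acid on that phenyl ring would do remains open.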